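Hydroxy in Place of Cyano on a Shared Core

The compounds below may be only part of what the source reports. "The series", "measured", "known", "first", "only" and "open" are said of these compounds alone.

Compound 2 `N#Cc1cc(N)ccc1-c1nc2ccccc2s1` and compound 1 `Cc1cc(N)ccc1-c1nc2ccccc2s1` are close relatives built on the same core. In a functional assay on MDA-MB-468 cells (Homo sapiens) for inhibition (a lower number here means a stronger inhibitor, a higher number a weaker inhibitor), compound 2 gives < 0.1 nM, which is a limit of the assay and not a number. In this assay compound 1 gives < 0.1 nM; < 0.1 nM (2 entries). Where compound 2 stands is therefore told only by the limit of < 0.1 nM in this assay, at which 1 of the 2 values shown sits, and no step between measured compounds can be sized from these entries.

Compound 3 `Nc1ccc(-c2nc3ccccc3s2)c(O)c1` differs from compound 2 by hydroxy in place of cyano on an aromatic carbon. Going by the values given here, no measured step covers this change, so the reasoning rests on compound 2 sitting at a limit. The estimated step of a number no lower from compound 2 to compound 3 (the limit leaves the size open) is expected to be small, hardly beyond the scatter, and the assay may again report only a limit. Compound 3 is thus expected to come in at 0.1 nM, with a range from 0.03 nM to 0.6 nM.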

Compound 3, half-maximal inhibitory concentration: > 10000 nM
Compound 3: a limit, no number (the forecaster's own chance of this, stated with the estimate: 50%); at least 100000-fold (5.00 log units) between middle value and limit.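

In this assay, hydroxy in place of cyano on an aromatic carbon gives an at least 100000-fold higher number from compound 2 to compound 3 (5.00 log units; beyond the scatter), so this position, ortho to a group of 9 heavy atoms and meta to an amino group, does not accept every small group equally. The earlier compounds shown here gave no sign of this, as compound 1 and compound 2 both stand at the same limit of the assay. Each end of the new step is a limit and not a number, so the step has no upper bound, and the true distance remains unknown: the limit of > 10000 nM in this assay, at which 1 of the 3 values shown sits.

The compounds shown do not tell whether the collapse is specific to hydroxy or would also follow with a methoxy or a carboxylic acid at this position. They also leave open how far a fluorine or a longer chain would be accepted there.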